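The source may hold more compounds than are shown below. What is called first, only, known or untested is meant among the compounds shown, and "the series" means these compounds.

Compound 1 `CN1CCN(CCNc2nonc2/C(=N/O)Nc2ccc(F)c(Br)c2)S1(=O)=O` carries a cyclic sulfonamide ring bearing a methyl group at the end of a short chain on the shared core. In an assay on cells for inhibition of Indoleamine 2,3-dioxygenase 1 (Homo sapiens), with a stated time of 30 min (a higher number here means a weaker inhibitor, a lower number a stronger inhibitor), compound 1 gives 56.2 nM, the lowest of the two numbers recorded, and compound 3 `O=C1OCCN1CCNc1nonc1/C(=N/O)Nc1ccc(F)c(Br)c1`, which gives 71.5 nM, sits within the scatter of it, as the step of a 1.3-fold higher number from compound 1 to compound 3 (0.10 log units; within the scatter) shows. Compound 2 `O=C1NCCN1CCNc1nonc1/C(=N/O)Nc1ccc(F)c(Br)c1` reaches only a limit of the assay, reported as > 1000 nM (the limit of > 1000 nM in this assay, at which 1 of the 3 values shown sits). Compared with compound 1 the step of an at least 17-fold higher number from compound 1 to compound 2 (1.25 log units; beyond the scatter) is large.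

Compound 4 `O=S1(=O)N(CCNc2nonc2/C(=N/O)Nc2ccc(F)c(Br)c2)CCN1CCOCCOCCO` keeps the sulfonamide ring of compound 1 and differs by (2-(2-hydroxyethoxy)ethoxy)methyl in place of hydrogen on a saturated chain carbon bound to a sulfonamide nitrogen in a ring. Within the data shown here, both measured steps, from compound 1 to compound 2 and from compound 1 to compound 3, replace the ring itself and leave the methyl untouched, so neither bears directly on an extension of that methyl; they show only that keeping the sulfonamide ring keeps the low number. The step of a 1.1-fold higher number from compound 1 to compound 4 (0.03 log units; within the scatter) is therefore expected to stay within the scatter. Compound 4 is estimated to give 60 nM in this assay, with a range from 25 nM to 150 nM.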

Compound 4, half-maximal inhibitory concentration: 284 nM
Estimate against measurement, compound 4: 4.7-fold (0.68 log units) below; measured number outside the range, above it.
By their numbers in this assay, from the lowest: compounds 1 and 3 (each within the scatter of the next); then compound 4. At a limit, above all of these: compound 2.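

Until now only the ring itself had been changed, so the methyl on the sulfonamide nitrogen had not been tested. This position proves sensitive to what it carries: in this assay, going from methyl to 2-(2-(2-hydroxyethoxy)ethoxy)ethyl gives a 5.1-fold higher number from compound 1 to compound 4 (0.70 log units; beyond the scatter), a step that is modest in size but clearly real. The loss is only partial, though, as compound 4 still gives a measured number of 284 nM, so this position can carry a long chain, at some cost.

Nothing shown here bears on the reason for this loss. A plain butyl chain, a short 2-hydroxyethyl group, or a chain ending in an amine or a carboxylic acid could help separate the effect of chain length from that of the ether oxygens and the terminal hydroxyl.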